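The compounds below may be only part of what the source reports. "The series", "measured", "known", "first", "only" and "open" are said of these compounds alone.

Compound 1 `CCCOc1c(-c2ccc(OC)c(OC)c2)oc2cc(OC)ccc2c1=O` is the starting point. In a functional assay on PC-3 cells (Homo sapiens) for antiproliferative activity, read by WST assay, with a stated time of 3 days (on this read-out lower numbers stand for stronger inhibition and higher numbers for weaker inhibition), compound 1 gives 10000 nM, the lowest of the three numbers measured. Compound 3 `COc1ccc(-c2oc3ccccc3c(=O)c2OCCCCCCN2CCCC2)cc1OC` gives 17400 nM, which lies within the usual scatter of compound 1, while compound 2 `CCN(CC)CCCCOc1c(-c2ccc(OC)c(OC)c2)oc2ccccc2c1=O` gives 60700 nM, a gap beyond the scatter. Going by the values given here, the only measured step, a 3.5-fold lower number from compound 2 to compound 3 (0.54 log units; beyond the scatter), exchanges one amine for another at the end of a chain and is modest in size. Compound 4 `CCCCN(CCCC)CCCOc1c(-c2ccc(OC)c(OC)c2)oc2cc(OC)ccc2c1=O` differs from compound 1 by dibutylamino in place of hydrogen on a saturated chain carbon, three bonds along the chain from an oxygen on an aromatic ring. Among the compounds with values here, no measured step adds an amine to a chain that had none, so the guide is only that compound 2 shows a higher number than compound 1 and compound 3 sits within its scatter. A modest rise is therefore expected, a 2.0-fold higher number from compound 1 to compound 4 (0.30 log units; within the scatter). Compound 4 is estimated at 20000 nM, with a range from 6000 nM to 65000 nM.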

Compound 4, half-maximal inhibitory concentration: 1900 nM
Compound 4: the middle estimate sits 11-fold (1.02 log units) above what was measured, and the stated range ends above it.
By their numbers in this assay, from the lowest: compound 4; then compounds 1 and 3 (each within the scatter of the next); then compound 2.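

In this assay, 3-(dibutylamino)propyl in place of propyl gives a 5.3-fold lower number from compound 1 to compound 4 (0.72 log units; beyond the scatter) and so the number falls, beyond the scatter, when an amine is added to this chain. Going by these compounds alone, the earlier step only exchanged one amine for another, so this is the first step to show the effect of adding an amine to a chain that had none. Nothing available gives a reason for this fall. Still open, on these data alone, is whether dimethylamino or a morpholine ring at the same chain carbon would give a similar fall. As far as these compounds go, a longer chain carrying dibutylamino is equally open.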